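Spiro-piperidine series: benzyl to isopentyl on the ring amine

The compounds below may be only part of what the source reports. "The series", "measured", "known", "first", "only" and "open" are said of these compounds alone.

Three compounds of the series have numbers in an assay for displacement of a labelled ligand from Sigma non-opioid intracellular receptor 1 (Cavia porcellus), read by scintillation counting, with a stated time of 180 min; on this read-out higher numbers stand for weaker inhibition and lower numbers for stronger inhibition. Compound 1 `COC1Cc2c(cnn2C)C2(CCN(CCC(C)C)CC2)O1` gives 18 nM, compound 2 `CC(C)CCN1CCC2(CC1)OCCc1c2cnn1-c1ccccc1` gives 0.98 nM, and compound 3 `Cn1ncc2c1CCOC21CCN(Cc2ccccc2)CC1` gives 9.2 nM. Compound 3 stands second highest of the three; its nearest neighbour is compound 1, whose number is within the usual scatter of that of compound 3, while compound 2 lies furthest away, with a number beyond the scatter below that of compound 3.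

Compound 4 `CC(C)CCN1CCC2(CC1)OCCc1c2cnn1C` has not been measured. It differs from compound 3 by isobutyl in place of phenyl on a saturated chain carbon bound to an amine nitrogen in a ring. Going by the values given here, both measured compounds that carry the isopentyl chain on the ring amine, compound 1 with 18 nM and compound 2 with 0.98 nM, bracket the number of compound 3, and no pair of measured compounds isolates this single change. For compound 4 the step from benzyl to isopentyl is therefore expected to be small, a 1.2-fold lower number from compound 3 to compound 4 (0.06 log units; within the scatter), in either direction but not beyond the scatter. Compound 4 is estimated at 8 nM, with a likely range from 2.5 nM to 30 nM in this assay.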

Compound 4, inhibition constant: 30 nM
For compound 4 the middle estimate is 3.8-fold (0.57 log units) below the measured one, and the stated range covers the measured number.
By their numbers in this assay, from the lowest: compound 2; then compounds 3, 1 and 4 (each within the scatter of the next, the first and the last beyond it).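

With the core fixed, the change from benzyl to isopentyl can now be read alone in this assay: a 3.3-fold higher number from compound 3 to compound 4 (0.51 log units; beyond the scatter) is a modest loss, so isobutyl does not fully stand in for phenyl on a saturated chain carbon bound to an amine nitrogen in a ring. The aromatic nitrogen matters much more, since methyl in place of phenyl there gives a 31-fold higher number from compound 2 to compound 4 (1.49 log units; beyond the scatter) and so accounts for the low number of compound 2. Hydrogen in place of methoxy on a saturated ring carbon gives a 1.7-fold higher number from compound 1 to compound 4 (0.22 log units; within the scatter) with no change beyond the scatter, so that position is tolerant in this one pair.

Nothing at hand gives a reason for any of these steps. Open, going by these compounds, is whether phenyl on the aromatic nitrogen also helps with benzyl on the amine, and how an ethyl group there or a longer chain on the amine would read.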